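The compounds below may be only part of what the source reports. "The series", "measured", "known", "first", "only" and "open" are said of these compounds alone.

Compound 1 `CCOCCn1c(N2CCN(C)CC2)nc2ccccc21` gives the lowest of the three numbers in a functional assay on ileum for inhibition of histamine H1 receptor (Cavia porcellus) (on this read-out lower numbers stand for stronger inhibition and higher numbers for weaker inhibition), at 10 nM. Compound 3 `CCSCCn1c(N2CCN(C)CC2)nc2ccccc21` gives 19 nM, and a 1.9-fold higher number from compound 1 to compound 3 (0.28 log units; within the scatter) lies within the scatter. Compound 2 `CCNCCn1c(N2CCN(C)CC2)nc2ccccc21` gives 290 nM, and a 29-fold higher number from compound 1 to compound 2 (1.46 log units; beyond the scatter) is large, as is a 15-fold lower number from compound 2 to compound 3 (1.18 log units; beyond the scatter). Compound 4 `CCCCN1CCN(c2nc3ccccc3n2CCOCC)CC1` differs from compound 1 by propyl in place of hydrogen on a saturated chain carbon bound to an amine nitrogen in a ring; the same difference, cut one bond further out, reads methyl to butyl. All three measured steps concern the chain on the aromatic nitrogen, and none touches the amine nitrogen in the ring, so none bears directly on this change. In this assay compound 4 is expected to show only a modest step of a 2.0-fold higher number from compound 1 to compound 4 (0.30 log units; within the scatter). Compound 4 is estimated at 20 nM (range 5 nM to 80 nM).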

Compound 4, half-maximal inhibitory concentration: 15 nM
Beside the measured number, compound 4's estimate is 1.3-fold (0.12 log units) above it; the measured number falls inside the stated range.
By their numbers in this assay, from the lowest: compounds 1, 4 and 3 (each within the scatter of the next); then compound 2.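

In this assay, the step for propyl in place of hydrogen on a saturated chain carbon bound to an amine nitrogen in a ring is a 1.5-fold higher number from compound 1 to compound 4 (0.18 log units; within the scatter) and so stays within the scatter. Among these compounds, this is the first reading at this position, and it shows that the methyl of compound 1 can be extended to butyl without a step beyond the scatter. Nothing available explains this result. From the compounds shown here alone, whether a longer chain, a benzyl group or a carboxylic acid would be accepted at this place remains open. So does whether butyl would give a similar step with ethylsulfanyl or ethylamino in place of ethoxy.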